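Aryl sulfonamide ether amides: liver microsome stability notes

A few compounds are considered here, and "the series" means these few. Any claim that something is new, unique, unknown or untested is made for them only; others in the source may bear on it.

Measured compounds:
compound 1 `COc1cc(C)c(S(=O)(=O)N(C)CCOCC(=O)N2CCC(N3CCN(C(C)C)CC3)CC2)c(C)c1`, 54%
compound 2 `CN(Cc1ccc(C2=NCCN2)cc1)C(=O)COCCN(C)S(=O)(=O)c1c(Cl)cccc1Cl`, "not determined" (no result reported)
compound 3 `COc1cc(C)c(S(=O)(=O)N(C)CCOCC(=O)N2CCN(C3CCN(C4CC4)CC3)CC2)c(C)c1`, 6%

In an ADME assay on microsomes from liver (Homo sapiens) for metabolic stability, with a stated time of 30 min, tested at 1 uM (on this read-out higher numbers stand for a more stable compound and lower numbers for a less stable compound), compound 1 gives 54% and compound 3 gives 6%; the two values lie far apart, beyond the usual scatter. Among the measured compounds shown here, compound 2 stands nowhere on these numbers: in this assay compound 2 gives "not determined" (no result reported), so no step from it can be sized or given a direction.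

Compound 4 `CN(Cc1ccc(C2=NCCN2)cc1)C(=O)COCCN(C)S(=O)(=O)c1ccccc1C(F)(F)F` differs from compound 2 in one place:
2-(trifluoromethyl)phenyl in place of 2,6-dichlorophenyl on a sulfonyl sulfur

With no value for compound 2, the expectation for compound 4 rests only on the range spanned by compound 1 and compound 3. Compound 4 is expected to give about 40% in this assay, estimated between 12% and 75%.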

Compound 4, percent of the compound remaining: 50%
Estimate against measurement, compound 4: 10 percentage points below, and the stated range covers the measured number.
By their numbers in this assay, from the lowest: compound 3; then compounds 4 and 1 (each within the scatter of the next).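

No new step can be read: compound 2 has no number in this assay, so the change to compound 4 cannot be sized. Nothing further bears on this result. Still open, going by these compounds, is how 2-(trifluoromethyl)phenyl compares with 2,6-dichlorophenyl on the sulfonyl sulfur.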